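The source may report more compounds than this note shows. Statements on the series, on what has been measured and on what is new or still open speak of the compounds shown alone.

Measured so far:
Compound 1 `CCN(C(=O)COc1ccc(C)cc1)C(C)c1cccs1` — "not active" (no number reported)
Compound 2 `CCN(Cc1ccoc1)C(=O)COc1ccc(C)cc1` — 136 nM
Compound 3 `CCN(Cc1cncs1)C(=O)COc1ccc(C)cc1` — 1100 nM

All three share one core and differ only in the group attached to the saturated chain carbon bound to the amide-type nitrogen. In an assay on HEK293 cells for agonist activity at transient receptor potential cation channel subfamily M member 8 (Homo sapiens), read by fluorescence and calcium flux, with a stated time of 15 min (a lower number here means that less compound is needed, a higher number that more compound is needed for the effect), compound 3 gives 1100 nM, the highest of the two numbers available; compound 2 gives 136 nM. For compound 1 no number was reported in this assay. Going by the values given here, the one measured step that compares these groups is an 8.1-fold higher number from compound 2 to compound 3 (0.91 log units; beyond the scatter).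

Compound 4 `CCN(Cc1ccco1)C(=O)COc1ccc(C)cc1` has not yet been measured. The change is furan-2-yl in place of 1,3-thiazol-5-yl on a saturated chain carbon bound to an amide-type nitrogen. This is close to the reverse of the measured step, with the furan joined through a different ring carbon. The step from compound 2 to compound 3 was an 8.1-fold higher number from compound 2 to compound 3 (0.91 log units; beyond the scatter), so a drop of roughly that order is expected here, though the shifted attachment point leaves room for a smaller or larger move. The expected step is a 5.5-fold lower number from compound 3 to compound 4 (0.74 log units; beyond the scatter), and compound 4 is estimated at 200 nM, within 60 nM to 700 nM.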

Compound 4, half-maximal effective concentration: 489 nM
Compound 4: the middle estimate sits 2.4-fold (0.39 log units) below what was measured, within the range that was stated.
By their numbers in this assay, from the lowest: compound 2; then compound 4; then compound 3.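

In this assay, the two furan compounds show that the point of attachment matters at this position, not just the type of ring: furan-2-yl in place of furan-3-yl gives a 3.6-fold higher number from compound 2 to compound 4 (0.56 log units; beyond the scatter). Furan-2-yl in place of 1,3-thiazol-5-yl gives a 2.2-fold lower number from compound 3 to compound 4 (0.35 log units; beyond the scatter), so compound 4 falls between the other two measured compounds and a furan ring alone does not secure the lowest number. Nothing available explains why the attachment point changes the result.

As far as these compounds go, it remains open how a phenyl or pyridine ring would behave on this saturated chain carbon, and whether a longer chain between the ring and the amide nitrogen would lower or raise the number. The effect of adding a methyl group to the furan ring is also unknown.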